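Phenyl for methyl on the oxadiazole: a second test

The source may report more compounds than this note shows. Statements on the series, on what has been measured and on what is new or still open speak of the compounds shown alone.

Measured so far in an assay on HL-60 cells for inhibition of glutathione S-transferase P (Homo sapiens); on this read-out lower numbers stand for stronger inhibition and higher numbers for weaker inhibition:
- compound 1 `C=C(C)C(=O)c1ccc(OCc2nc(C)no2)cc1C` gives 5000 nM
- compound 2 `C=C(C)C(=O)c1ccc(OCc2nc(-c3ccccc3)no2)cc1C` gives 1970 nM
- compound 3 `C=C(CC)C(=O)c1ccc(OCc2nc(C)no2)c(Cl)c1Cl` gives 4000 nM

Compound 2 differs from compound 1 by one change (phenyl in place of methyl on an aromatic carbon), and that change gave a 2.5-fold lower number from compound 1 to compound 2 (0.40 log units; beyond the scatter). Compound 3 has a different core; how its core differs from that of compound 1 is not broken down here. Compound 4 `C=C(CC)C(=O)c1ccc(OCc2nc(-c3ccccc3)no2)c(Cl)c1Cl` is not yet measured. It differs from compound 3 by phenyl in place of methyl on an aromatic carbon, the same change that turned compound 1 into compound 2, at the same place. Because compound 1 to compound 2 gave a 2.5-fold lower number from compound 1 to compound 2 (0.40 log units; beyond the scatter), a step of similar size is expected here, that is a 2.5-fold lower number from compound 3 to compound 4 (0.40 log units; beyond the scatter), resting on that single earlier example alone. Compound 4 is therefore estimated at 1600 nM, likely between 700 nM and 3500 nM.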

Compound 4, half-maximal inhibitory concentration: 3600 nM
Compound 4: middle estimate off by 2.3-fold (0.35 log units), on the low side; measured number outside the range, above it.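

On the core of compound 3, phenyl in place of methyl gave a 1.1-fold lower number from compound 3 to compound 4 (0.05 log units; within the scatter), so the clear step seen on the core of compound 1 is not matched here. Set side by side, the two steps cannot be told apart: the same change on two cores in this assay, a 2.5-fold lower number (0.40 log units; beyond the scatter) from compound 1 to compound 2 and a 1.1-fold lower number (0.05 log units; within the scatter) from compound 3 to compound 4, 2.3-fold (0.36 log units) apart, within the scatter of two such steps. Among the compounds shown here, the pair therefore neither proves that the change carries over from one core to the other nor proves that its effect depends on the core; with only two steps, a real difference between cores and ordinary scatter look alike.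

Going by these compounds, it remains open how an amine, a carboxylic acid or a longer chain at this place on the five-membered aromatic ring would behave on either core. A third core carrying the same change could also help settle the question.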